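Trading the Ester Arm for a Bulky Amine Substituent

The source may report more compounds than this note shows. Statements on the series, on what has been measured and on what is new or still open speak of the compounds shown alone.

Measured so far:
Compound 1 `CC(C)=CCc1cc(C(=O)Nc2cc3ccc(OCC4CCCN(C)C4)c(C)c3oc2=O)ccc1O` gives 2640 nM in a functional assay on MCF7 cells (Homo sapiens) for antiproliferative activity; a higher number here means a weaker inhibitor, a lower number a stronger inhibitor.
Compound 2 `CCCN(CCC)CCCOc1ccc2cc(NC(=O)c3ccc(O)c(CC=C(C)C)c3)c(=O)oc2c1C` reaches only a limit of the assay, > 50000 nM in this assay.
Compound 3 `COC(=O)CNCCCOc1ccc2cc(NC(=O)c3ccc(O)c(CC=C(C)C)c3)c(=O)oc2c1C` gives 2820 nM in this assay.

Among the two plain numbers, compound 3 stands together with compound 1: the step of a 1.1-fold higher number from compound 1 to compound 3 (0.03 log units; within the scatter) is within the scatter, so the two cannot be told apart. Compound 2 sits at the limit (the limit of > 50000 nM in this assay, at which 1 of the 3 values shown sits).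

Compound 4 `CC(C)=CCc1cc(C(=O)Nc2cc3ccc(OCCCNC(C)(C)c4ccccc4)c(C)c3oc2=O)ccc1O` is the next compound to be measured. It differs from compound 3 in one place: 1-methyl-1-phenylethyl in place of (methoxycarbonyl)methyl on an amine nitrogen.

For the measured compounds named here, two measured steps bear on this. From compound 2 to compound 3 the change was large, an at least 17-fold lower number from compound 2 to compound 3 (1.24 log units; beyond the scatter), and from compound 1 to compound 2 likewise, an at least 18-fold higher number from compound 1 to compound 2 (1.27 log units; beyond the scatter). Both show that the amine substituent on this chain decides the outcome, and that an amine carrying only carbon substituents went to the limit, while the ester-bearing amine and the ring amine stayed at moderate numbers. Compound 4 again carries an amine substituent of carbon only, though the amine hydrogen is kept.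

Compound 4 is therefore expected to show a rise, a 3.2-fold higher number from compound 3 to compound 4 (0.50 log units; beyond the scatter), with a real chance of a limit. The estimate for compound 4 is 9000 nM, between 2500 nM and 50000 nM.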

Compound 4, half-maximal inhibitory concentration: 1070 nM
Beside the measured number, compound 4's estimate is 8.4-fold (0.92 log units) above it; measured number outside the range, below it.
By their numbers in this assay, from the lowest: compound 4; then compounds 1 and 3 (each within the scatter of the next). At a limit, above all of these: compound 2.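

In this assay, 1-methyl-1-phenylethyl on the amine nitrogen in place of (methoxycarbonyl)methyl gives a 2.6-fold lower number from compound 3 to compound 4 (0.42 log units; beyond the scatter) and so a modest gain, and the comparison with the ring amine gives a 2.5-fold lower number from compound 1 to compound 4 (0.39 log units; beyond the scatter) in the same direction. For the compounds shown here, the ester arm is therefore not required for a moderate number on this chain, and a substituent of carbon only does not by itself lead to the limit, as the earlier compounds had left possible. The contrast with the dipropylamino group is large, at an at least 46-fold lower number from compound 2 to compound 4 (1.66 log units; beyond the scatter) as the step reads, so two amines bearing only carbon substituents end far apart, and compound 1, with its ring amine, also goes against any simple rule of that kind, while compound 2 remains a limit and not a number: the limit of > 50000 nM in this assay, at which 1 of the 4 values shown sits.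

The compounds shown leave open whether the gain in compound 4 belongs to the amine hydrogen it keeps or to its phenyl ring, since these two features change together. A simple secondary amine carrying one propyl group, a benzyl group on the same nitrogen, a carboxylic acid in place of the methyl ester or a longer chain would each separate these readings.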